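Notes on substitution of the sulfonamide nitrogen

The compounds below may be only part of what the source reports. "The series", "measured", "known", "first", "only" and "open" are said of these compounds alone.

Compound 1 `CC1(C)C=C(n2ccccc2=O)c2cc(S(N)(=O)=O)ccc2O1` carries an unsubstituted sulfonamide; in a functional assay with Rattus norvegicus as the target (on this read-out higher numbers stand for an effect only at larger amounts of compound and lower numbers for an effect already at smaller amounts), compound 1 gives 69.2 nM. Going by the values given here, compound 2 `CC1(C)C=C(n2ccccc2=O)c2cc(S(=O)(=O)Nc3ccc(C#N)cc3)ccc2O1` bears 4-cyanophenyl on that nitrogen, and in this assay compound 2 gives the higher of the two numbers, 263 nM; the only measured step, a 3.8-fold higher number from compound 1 to compound 2 (0.58 log units; beyond the scatter), is what separates it from compound 1. Compound 3 `CC1(C)C=C(n2ccccc2=O)c2cc(S(=O)(=O)NC(=O)Nc3ccccc3)ccc2O1` is the next variation: phenylcarbamoyl in place of 4-cyanophenyl on a sulfonamide nitrogen. Among the compounds with values here, no measured pair exchanges one substituent on the sulfonamide nitrogen for another, so the one step that bears on this change is the move from an unsubstituted to a substituted nitrogen, a 3.8-fold higher number from compound 1 to compound 2 (0.58 log units; beyond the scatter), which was modest. A substituted nitrogen is retained in compound 3, so the expectation for a 1.1-fold higher number from compound 2 to compound 3 (0.06 log units; within the scatter) is a step not beyond the scatter, in either direction. For compound 3 the estimated value in this assay is 300 nM, with a range from 110 nM to 850 nM.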

Compound 3, half-maximal effective concentration: 1410 nM
The estimate for compound 3 lay 4.7-fold (0.67 log units) below the measured number, and the stated range ends below it.
By their numbers in this assay, from the lowest: compound 1; then compound 2; then compound 3.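

The sulfonamide nitrogen does not treat its substituents alike: in this assay exchanging one substituent for another there gives a 5.4-fold higher number from compound 2 to compound 3 (0.73 log units; beyond the scatter), so a substituted nitrogen cannot be read as a single class. Relative to the unsubstituted nitrogen, phenylcarbamoyl gives a 20-fold higher number from compound 1 to compound 3 (1.31 log units; beyond the scatter), a large step that exceeds the modest one seen with 4-cyanophenyl. Nothing available bears on the reason for the difference between these two substituents.

Because 4-cyanophenyl and phenylcarbamoyl differ in more than one feature, the compounds shown cannot assign the step to the nitrile, the carbonyl or the added hydrogen-bond donor. Also open, on these data alone, is where a plain phenyl, a methyl or an acetyl group on this nitrogen would fall relative to compound 1 and compound 2.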